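A few compounds are considered here, and "the series" means these few. Any claim that something is new, unique, unknown or untested is made for them only; others in the source may bear on it.

Measured compounds:
Compound 1, `CCCCOc1cc(C(=O)NC)nn1-c1ccccc1`: 65%
Compound 2, `CCCCOc1cc(C(=O)NC(C)C)nn1-c1ccccc1`: 15.8%
Compound 3, `CCCCOc1cc(C(=O)N2CCCC2)nn1-c1ccccc1`: 17.6%

In a functional assay on the whole organism (strain Wistar) for inhibition, with Rattus norvegicus as the target, read by paw edema, with stated times of 30 min and 3 h, at a dose of 100 mg/kg by the oral route (on this read-out lower numbers stand for less inhibition and higher numbers for more inhibition at the one dose given (going by the name of the read-out)), compound 3 stands second highest of the three numbers. Its nearest neighbour is compound 2, and the step of a number 1.8 percentage points higher from compound 2 to compound 3 (within the scatter) lies within the scatter, so the two cannot be told apart on these data. Its furthest neighbour is compound 1, from which compound 3 is separated by a number 47.4 percentage points lower from compound 1 to compound 3 (beyond the scatter), a large drop. Compound 4, `CCCCOc1cc(C(=O)N2CCCCC2)nn1-c1ccccc1`, has not yet been measured. It differs from compound 3 as follows: piperidin-1-yl in place of pyrrolidin-1-yl on a carbonyl carbon. Going by the values given here, of the measured steps, the one from compound 2 to compound 3 bears most on this change, since it too alters only the group on the carbonyl carbon among compounds that all lack the methylamino group of compound 1, and it stayed within the scatter. The large steps from compound 1 were tied to leaving methylamino, which compound 4 has already left. Compound 4 is therefore expected to stay close to compound 3, with an expected step of a number 0.4 percentage points higher from compound 3 to compound 4 (within the scatter). Compound 4 is estimated at 18%, within a range from 5% to 35%.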

Compound 4, a percentage reported as inhibition, in the whole organism at one dose (the size of the read-out at that dose, not a potency): 15.6%
The estimate for compound 4 lay 2.4 percentage points above the measured number, and the stated range covers the measured number.
By their numbers in this assay, from the lowest: compounds 4, 2 and 3 (each within the scatter of the next); then compound 1.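

In this assay, going from pyrrolidin-1-yl to piperidin-1-yl on the carbonyl carbon gives a number 2 percentage points lower from compound 3 to compound 4 (within the scatter), so this difference in ring size has no readable effect at this position. Piperidin-1-yl also cannot be told apart from isopropylamino, with a number 0.2 percentage points lower from compound 2 to compound 4 (within the scatter), which shows that the ring is not what matters among these three groups. Piperidin-1-yl repeats the large gap from methylamino, with a number 49.4 percentage points lower from compound 1 to compound 4 (beyond the scatter), leaving compound 1 alone among the four compounds shown. Nothing given here explains why the methylamino compound stands apart from the other three.

From the compounds shown here alone, it remains open where an unsubstituted amide, an ethylamino group or a morpholin-4-yl group on the carbonyl carbon would fall. Going by these compounds, it is also open whether methylamino would keep its gap if a shorter alkoxy chain replaced the butoxy chain.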